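A few compounds are considered here, and "the series" means these few. Any claim that something is new, unique, unknown or untested is made for them only; others in the source may bear on it.

Working notes on the series, read out in a functional assay on the whole organism with Rattus norvegicus as the target (a higher number here means that more compound is needed for the effect, a lower number that less compound is needed), throughout. Compound 2 (`N=c1sc2cc(OC(F)(F)F)ccc2n1CCS`) gives 2 mg/kg and compound 1 (`CSCn1c(=N)sc2cc(OC(F)(F)F)ccc21`) gives 3 mg/kg so the two stand within the scatter of each other and neither can be ranked. Compound 3 (`CSCCCn1c(=N)sc2cc(OC(F)(F)F)ccc21`) has no number yet. Going to it from compound 2, the change is (methylsulfanyl)methyl in place of sulfanyl on a saturated chain carbon, two bonds along the chain from an aromatic nitrogen and in words this is (methylsulfanyl)methyl in place of sulfanyl on a saturated chain carbon, two bonds along the chain from an aromatic nitrogen. Among the measured compounds shown here, only one measured step bears on this, namely a 1.5-fold lower number from compound 1 to compound 2 (0.18 log units; within the scatter) and it too exchanges one sulfur-bearing chain end for another. Compound 3 keeps the methylsulfanyl end of compound 1 on a longer chain, a length not yet tested, so a single step within the scatter is thin support. No shift beyond the scatter is expected in this assay at this stage. The expected size is a 1.5-fold higher number from compound 2 to compound 3 (0.18 log units; within the scatter) and the range stays wide. For compound 3 the estimate is 3 mg/kg with an expected range from 1.2 mg/kg to 9 mg/kg for now.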

Compound 3, dose for half-maximal effect: 4.2 mg/kg
Compound 3: middle estimate off by 1.4-fold (0.15 log units), on the low side; the range from low to high includes it.
By their numbers in this assay, from the lowest: compounds 2, 1 and 3 (each within the scatter of the next, the first and the last beyond it).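

In this assay, among the compounds shown here, (methylsulfanyl)methyl in place of sulfanyl, on a saturated chain carbon, two bonds along the chain from an aromatic nitrogen, gives a 2.1-fold higher number from compound 2 to compound 3 (0.32 log units; beyond the scatter) and is the first step at this position to pass the scatter, so the group carried here is not wholly without consequence, though the step is modest. The other new step, which keeps the methylsulfanyl end and carries it on a 3-(methylsulfanyl)propyl chain, gives a 1.4-fold higher number from compound 1 to compound 3 (0.15 log units; within the scatter) and so does not separate the two compounds that end in methylsulfanyl. Nothing available here accounts for the modest step.

That step exchanges a 2-sulfanylethyl for a 3-(methylsulfanyl)propyl, with the hydrogen-bond donor count going from 1 to 0, so the share of the chain end and the share of the chain length in it cannot be told apart. A 3-sulfanylpropyl group, or a chain ending in an amine or a carboxylic acid at this position, would bear on whether the sulfur end matters at all in this assay.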